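A few compounds are considered here, and "the series" means these few. Any claim that something is new, unique, unknown or untested is made for them only; others in the source may bear on it.

Of the compounds shown here, two built on a shared core have been tested in an ADME assay on Huh-7 cells (Homo sapiens) for cytotoxicity, read by a luciferase reporter and WST assay, with a stated time of 3 days; a lower number here means that less compound is tolerated, a higher number that more compound is tolerated. In this assay compound 1 `O=C(Nc1ccccc1)c1c(NO)cc(-c2ccc(F)cc2)oc1=O` gives 10300 nM. Compound 2 `O=C(Nc1ccc(Cl)cc1)c1c(NO)cc(-c2ccccc2)oc1=O` returns in this assay only a limit of the assay, > 20000 nM, so its place on the scale is known only as a range rather than a number. Of the two values given, one sits at the limit of > 20000 nM in this assay, at which 1 of the 2 values shown sits. Compound 3 `Cc1ccc(NC(=O)c2c(NO)cc(-c3ccccc3)oc2=O)cc1` has not yet been measured; it differs from compound 2 by methyl in place of chloro on an aromatic carbon. Going by the values given here, no measured pair differing in this way is available, so the size of the step can only be expected. The step that the limit leaves unreadable from compound 2 to compound 3 is expected to be none beyond the scatter, in this assay. Compound 3 is estimated at 25000 nM, with a range from 10000 nM to 60000 nM.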

Compound 3, half-maximal cytotoxic concentration: > 20000 nM
Compound 3 gave a limit, no number (the forecaster's own chance of this, stated with the estimate: 60%); the middle value does not contradict the limit.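

Compound 2 and compound 3 both return only a limit in this assay, so no step between them can be read: the limit of > 20000 nM in this assay, at which 2 of the 3 values shown sit.

The compounds shown leave open how large a step methyl in place of chloro on an aromatic carbon produces in this assay.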